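The compounds below may be only part of what the source reports. "The series", "measured", "known", "first", "only" and "open" are said of these compounds alone.

For the measured compounds named here, compound 2, `Cc1ccc(-c2nc3ccccc3s2)cc1NC(=O)c1cc([N+](=O)[O-])c(N2CCC(C(=O)O)CC2)cc1Cl`, is one of three compounds measured in an ADME assay on Raji cells (Homo sapiens) for cytotoxicity, with a stated time of 72 h; a lower number here means that less compound is needed, a higher number that more compound is needed for the effect. In this assay compound 2 gives > 25000 nM, which is a limit of the assay and not a number. Compound 1, `Cc1ccc(-c2nc3ccccc3s2)cc1NC(=O)c1cc([N+](=O)[O-])c(N2CCCCC2)cc1Cl`, carries hydrogen where compound 2 carries carboxy on a saturated ring carbon. In this assay compound 1 gives > 25000 nM, again a limit. The step that the two limits leave unreadable from compound 1 to compound 2 is therefore of unreadable size. Compound 3, `O=C(Nc1cccc(-c2nc3ccccc3o2)c1)c1cc([N+](=O)[O-])ccc1Cl`, shares only part of its skeleton with the other two. In this assay compound 3 gives > 25000 nM, also a limit. The whole picture so far is the limit of > 25000 nM in this assay, at which 3 of the 3 values shown sit.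

The unmeasured compound 4, `Cc1ccc(-c2nc3ccccc3s2)cc1NC(=O)c1cc([N+](=O)[O-])c(N(C)C)cc1Cl`, differs from compound 2 in one place: dimethylamino in place of 4-carboxypiperidin-1-yl on an aromatic carbon. Going by the values given here, no measured step touches this change directly; the only step available is a step that the two limits leave unreadable from compound 1 to compound 2, whose size the two limits leave unreadable. Nothing shown moves away from the limit, so compound 4 is expected to stay there as well. The expected step is therefore a step that the limit leaves unreadable from compound 2 to compound 4, with a good chance that only a limit is reported again. The estimate for compound 4 is 40000 nM, with a range from 25000 nM to 100000 nM.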

Compound 4, half-maximal effective concentration: > 25000 nM
Compound 4 gave a limit, no number; the forecaster's own chance of this, stated with the estimate: 85%; the middle value does not contradict the limit.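

In this assay compound 4 gives > 25000 nM, a limit of the assay and not a number, so the steps from compound 4 to compound 1 and to compound 2 cannot be read. The overall picture is: the limit of > 25000 nM in this assay, at which 4 of the 4 values shown sit. The compounds shown leave open what size any of these changes has in this assay, as none yields a number.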